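This account rests on a few compounds, and the source may have more. Where it says the series, first, only, none or still open, it means among the compounds named here.

Three compounds with a shared core have been examined in a physicochemical assay for solubility, read by HPLC, in phosphate buffer, measured as kinetic solubility, at pH 7.4; on this read-out higher numbers stand for higher solubility and lower numbers for lower solubility. Compound 1, `CC(=O)c1cc(-c2ccc(Cl)cc2)n(-c2ccc(S(N)(=O)=O)cc2)c1C`, gives 2700 nM in this assay. Compound 2, `CCC(=O)c1cc(-c2ccc(F)cc2)n(-c2ccc(S(N)(=O)=O)cc2)c1`, gives 63000 nM. Compound 3, `CC(C)(C)C(=O)c1cc(-c2ccc(S(N)(=O)=O)cc2)n(-c2ccc(Cl)cc2)n1`, gives 6600 nM, which places it second highest of the three numbers: compound 1 sits lower, and compound 2 sits higher, both gaps lying beyond the usual scatter of repeated measurements. No pair among these three differs in only one place, so no single-point step can be read from the measured set.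

Compound 4, `CN(C(=O)c1cc(-c2ccc(S(N)(=O)=O)cc2)n(-c2ccc(Cl)cc2)n1)C1CC1`, has not yet been measured in this assay. It is obtained from compound 3 by one change: cyclopropyl(methyl)amino in place of tert-butyl on a carbonyl carbon. The tert-butyl that leaves and the cyclopropyl(methyl)amino that enters both carry no donors, no acceptors and no charge, and they differ by one heavy atom and by the three-membered ring of carbon only.

Among the compounds with values here, no measured step of this kind is available, so any expectation rests on the value of compound 3 alone. The account expects compound 4 to reach a somewhat higher number than compound 3, the step of a 2.3-fold higher number from compound 3 to compound 4 (0.36 log units; beyond the scatter) being modest and possibly no larger than the scatter. On that basis compound 4 is estimated at 15000 nM, within a range from 4000 nM to 60000 nM.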

Compound 4, solubility: 99600 nM
The estimate for compound 4 lay 6.6-fold (0.82 log units) below the measured number; measured number outside the range, above it.
By their numbers in this assay, from the lowest: compound 1; then compound 3; then compounds 2 and 4 (each within the scatter of the next).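

Until now no single-place step could be read from the set, and here the first one appears: in this assay cyclopropyl(methyl)amino in place of tert-butyl on a carbonyl carbon gives a 15-fold higher number from compound 3 to compound 4 (1.18 log units; beyond the scatter) at this position. The position is thus far from indifferent on this read-out: the change, which can also be read as (tert-butyl)carbonyl to cyclopropyl(methyl)carbamoyl, adds one heavy atom, a nitrogen and a three-membered ring of carbon only, while the counts of hydrogen-bond donors and acceptors and the net charge stay the same, and the step is still large. No measurement at hand explains the size of this step or assigns it to any one part of the entering group.

The compounds shown leave open whether the nitrogen or the cyclopropyl ring carries the step, a question that a dimethylamino group or a piperidine on the same carbonyl carbon could help to separate. They also leave open whether the same exchange gives a step of similar size on the cores of compound 1 and compound 2, which carry other groups on their carbonyl carbons.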